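The source may report more compounds than this note shows. Statements on the series, on what has been measured and on what is new or still open speak of the compounds shown alone.

Of the compounds shown here, two of a shared core have been measured in a functional assay on KB cells (Homo sapiens) for cytotoxicity; on this read-out higher numbers stand for weaker inhibition and lower numbers for stronger inhibition. Compound 1 `COc1ccc(S(=O)(=O)N2CCc3cc(Br)cc(NC(=O)c4ccco4)c32)cc1` gives 89 nM, while compound 2 `COc1ccc(C(=O)Nc2cccc3c2N(S(=O)(=O)c2ccc(OC)cc2)CC3)cc1` gives 2600 nM. Compound 2 therefore stands at the highest, and so the weakest, of the two numbers, with compound 1 coming out a good deal lower, a gap well beyond the usual scatter. Going by the values given here, the two differ in more than one place, so no single step links them.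

Compound 3 `COc1ccc(S(=O)(=O)N2CCc3cccc(NC(=O)C(C)(C)C)c32)cc1` has not yet been measured in this assay. It is derived from compound 2 by one change: tert-butyl in place of 4-methoxyphenyl on a carbonyl carbon. Because compound 2 sits at 2600 nM and the only other number shown, for compound 1, is far lower, compound 3 is expected to move toward stronger inhibition by an estimated step of a 2.6-fold lower number from compound 2 to compound 3 (0.41 log units; beyond the scatter), though with wide uncertainty. The estimate for compound 3 in this assay is 1000 nM, within a range from 200 nM to 6000 nM.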

Compound 3, half-maximal inhibitory concentration: 359 nM
The estimate for compound 3 lay 2.8-fold (0.44 log units) above the measured number; low and high end bracket the measured number.
By their numbers in this assay, from the lowest: compound 1; then compound 3; then compound 2.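

In this assay, going by these compounds alone, tert-butyl in place of 4-methoxyphenyl on a carbonyl carbon gives a 7.2-fold lower number from compound 2 to compound 3 (0.86 log units; beyond the scatter) and shows for the first time that what sits on this carbonyl carbon alters the read-out. An aromatic ring at this place is not required for inhibition in this pair: tert-butyl has no ring, fewer heavy atoms and no hydrogen-bond acceptor, yet it gives the lower number. No other measurement bears on why the number falls, so the step remains unexplained.

Going by these compounds, whether the gain comes from losing the ring or the methoxy group stays open, and plain phenyl, methyl or a cyclohexyl ring on the same carbonyl carbon would each test a different part of that question. Compound 1 differs from compound 2 and compound 3 in more than one place, so its lower value cannot be assigned to any single group.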